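Oxadiazole in place of isopropoxycarbonyl on the ring nitrogen

The source may report more compounds than this note shows. Statements on the series, on what has been measured and on what is new or still open speak of the compounds shown alone.

Working notes on the series. In a functional assay for agonist activity at Glucose-dependent insulinotropic receptor (Mus musculus), read by HTRF and cAMP accumulation, with a stated time of 45 min (a lower number here means that less compound is needed, a higher number that more compound is needed for the effect), compound 1 `CC(C)(C)OC(=O)N1C[C@@H]2CC[C@H]1CN2c1ncc(OCc2ccc(S(C)(=O)=O)cc2)cn1` gives > 30000 nM, which is a limit of the assay and not a number (the limit of > 30000 nM in this assay, at which 1 of the 3 values shown sits). Compound 2 `Cc1cnccc1COc1cnc(N2CCN(C(=O)OC(C)(C)C)C[C@H]2C)nc1` gives 236 nM in this assay. Compound 3 `CC(C)OC(=O)N1CCN(c2ncc(OCc3ccncc3C#N)cn2)[C@H](C)C1` gives 458 nM in this assay; of the two numbers on hand it is the higher, but the gap to compound 2 falls within the usual scatter of repeat measurements, so no order between compound 2 and compound 3 is claimed.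

Compound 4 `C[C@@H]1CN(c2noc(C3CC3)n2)CCN1c1ncc(OCc2ccncc2C#N)cn1` has not yet been measured. It differs from compound 3 in one place: 5-cyclopropyl-1,2,4-oxadiazol-3-yl in place of isopropoxycarbonyl on an amine nitrogen in a ring. Going by the values given here, no measured pair in the set carries this change or a related one, so there is no measured step to lean on, and the two compounds that are not limits sit close together. The expectation is therefore a step that stays within the scatter, with no clear direction. For compound 4 the estimated value in this assay is 320 nM, with a range from 80 nM to 1500 nM. This estimate means an expected step from compound 3 to compound 4 of a 1.4-fold lower number from compound 3 to compound 4 (0.16 log units; within the scatter), which is expected to lie within the scatter.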

Compound 4, half-maximal effective concentration: 89 nM
Compound 4: middle estimate off by 3.6-fold (0.56 log units), on the high side; measured number inside the range.
By their numbers in this assay, from the lowest: compound 4; then compounds 2 and 3 (each within the scatter of the next). At a limit, above all of these: compound 1.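

In this assay, going by these compounds alone, 5-cyclopropyl-1,2,4-oxadiazol-3-yl in place of isopropoxycarbonyl on the amine nitrogen in the ring gives a 5.1-fold lower number from compound 3 to compound 4 (0.71 log units; beyond the scatter), the first step that can be read at all and one that lies beyond the scatter. At this position, then, a carbonyl group on the ring nitrogen is not needed to keep activity in this pair: the entering group has no double bond outside its aromatic ring, and the number still falls, so the position accepts a larger group with two rings in place of an open-chain one. Nothing measured in the series gives a reason for the size of this step.

Within the data shown here, the single pair does not separate the contribution of the five-membered aromatic ring from that of the three-membered ring, and a methyl, an isopropyl or a trifluoromethyl in place of the cyclopropyl on the same oxadiazole would be needed to tell them apart. Going by these compounds, it also stays open whether other groups on this nitrogen, such as an amide, a urea or a pyrimidine, follow the same direction, and whether the step carries over to other cores.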